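Fluoro-trifluoromethylphenyl variant in the orexin-2 series

This account rests on a few compounds, and the source may have more. Where it says the series, first, only, none or still open, it means among the compounds named here.

Among the measured compounds shown here, compound 2 `CNC(=O)[C@@H](c1ccccc1)N1CCn2c(C3CC3)nc(Cl)c2[C@@H]1CCc1cccc(C(F)(F)F)c1` carries a 3-(trifluoromethyl)phenyl on the chain and in a functional assay on CHO cells for antagonist activity at Orexin receptor type 2 (Homo sapiens), read by FLIPR and calcium flux (a lower number here means a stronger inhibitor, a higher number a weaker inhibitor), compound 2 gives 7 nM, the lowest of the two numbers so far; compound 1 `CNC(=O)[C@@H](c1ccccc1)N1CCn2c(C3CC3)nc(Cl)c2[C@@H]1CCc1ccc(C(F)(F)F)cc1` with a 4-(trifluoromethyl)phenyl gives 9 nM in this assay, and the two stand within the scatter of each other, the only measured step being a 1.3-fold lower number from compound 1 to compound 2 (0.11 log units; within the scatter). Compound 3 `CNC(=O)[C@@H](c1ccccc1)N1CCn2c(C3CC3)nc(Cl)c2[C@@H]1CCc1ccc(C(F)(F)F)c(F)c1` has not been measured; it differs from compound 2 by 3-fluoro-4-(trifluoromethyl)phenyl in place of 3-(trifluoromethyl)phenyl on a saturated chain carbon, two bonds along the chain from a saturated ring carbon. The step from compound 1 to compound 2 bears on it, since it covers the 4-(trifluoromethyl)phenyl against the 3-(trifluoromethyl)phenyl and was within the scatter. For the measured compounds named here, the added fluorine on the ring has no counterpart among the measured compounds. From the step between compound 1 and compound 2 alone, the expectation for compound 3 in this assay is a step of a 1.1-fold higher number from compound 2 to compound 3 (0.06 log units; within the scatter), not beyond the scatter in either direction. Compound 3 is therefore estimated at 8 nM in this assay, with a range from 3 nM to 22 nM.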

Compound 3, half-maximal inhibitory concentration: 10 nM
Beside the measured number, compound 3's estimate is 1.3-fold (0.10 log units) below it; measured number inside the range.
By their numbers in this assay, from the lowest: compounds 2, 1 and 3 (each within the scatter of the next).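

In this assay, among the compounds shown here, fluoro in place of hydrogen on an aromatic carbon is now measured for the first time, and on the 4-(trifluoromethyl)phenyl of compound 1 it reads as a 1.1-fold higher number from compound 1 to compound 3 (0.05 log units; within the scatter), so this ring accepts the added fluorine with no change that can be told from the scatter. The other route to the same compound, a 1.4-fold higher number from compound 2 to compound 3 (0.15 log units; within the scatter), is also within the scatter, which means that 3-(trifluoromethyl)phenyl, 4-(trifluoromethyl)phenyl and 3-fluoro-4-(trifluoromethyl)phenyl cannot be separated at this place on the chain, and the position has so far shown no sensitivity to any of these three aryl groups. Nothing available offers an explanation for these readings.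

Open, from the compounds shown here alone, is whether this flat reading extends to a chlorine, a methoxy or a nitrile on the same ring, or to an unsubstituted phenyl with the trifluoromethyl removed. Also open, going by these compounds, is whether a pyridine in place of the phenyl, or a longer chain carrying the ring, would give a step beyond the scatter.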